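Chloro-to-nitro swap in a sulfonamide series against leukemia cells

The compounds below may be only part of what the source reports. "The series", "measured", "known", "first", "only" and "open" are said of these compounds alone.

Measured so far:
compound 1 `O=C(NCCNS(=O)(=O)c1ccc(-c2ccccc2Oc2ccc([N+](=O)[O-])c([N+](=O)[O-])c2)s1)Nc1ccc([N+](=O)[O-])cc1`, 3000 nM
compound 2 `O=S(=O)(c1sccc1-c1ccccc1Oc1ccc(O)c(O)c1)N1CCN(C(=S)Nc2ccc(Cl)cc2)CC1`, 7500 nM
compound 3 `O=C(NCCNS(=O)(=O)c1ccc(-c2ccccc2Oc2ccc([N+](=O)[O-])c([N+](=O)[O-])c2)s1)Nc1ccc(Cl)cc1`, 6700 nM

All three were tested in a functional assay on RS4-11 cells (Homo sapiens) for inhibition, read by CCK-8 assay, with a stated time of 48 h; a higher number here means a weaker inhibitor, a lower number a stronger inhibitor. Compound 3 and compound 1 differ in one place, (nitro in place of chloro on an aromatic carbon), and this gave a 2.2-fold lower number from compound 3 to compound 1 (0.35 log units; beyond the scatter). Compound 2 gives the highest number of the three; its gap to compound 3 lies within the scatter, while its gap to compound 1 lies beyond it. The difference between the core of compound 2 and the core of compound 3 is not broken down here.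

Compound 4 `O=[N+]([O-])c1ccc(NC(=S)N2CCN(S(=O)(=O)c3sccc3-c3ccccc3Oc3ccc(O)c(O)c3)CC2)cc1` has not yet been measured. It arises from compound 2 by the same change, (nitro in place of chloro on an aromatic carbon), at a place described in the same words as before. Because a 2.2-fold lower number from compound 3 to compound 1 (0.35 log units; beyond the scatter) was seen for that change, a step of similar size, a 2.1-fold lower number from compound 2 to compound 4 (0.33 log units; beyond the scatter), is expected here. Compound 4 is therefore estimated at 3500 nM, most likely between 1500 nM and 8000 nM.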

Compound 4, half-maximal inhibitory concentration: 9000 nM
Beside the measured number, compound 4's estimate is 2.6-fold (0.41 log units) below it, and the stated range ends below it.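

On the core of compound 2, nitro in place of chloro did not repeat what it had done on the core of compound 3: in this assay the change gave a 1.2-fold higher number from compound 2 to compound 4 (0.08 log units; within the scatter). The two steps do not agree: the same change on two cores in this assay, a 2.2-fold lower number (0.35 log units; beyond the scatter) from compound 3 to compound 1 and a 1.2-fold higher number (0.08 log units; within the scatter) from compound 2 to compound 4, 2.7-fold (0.43 log units) apart, beyond the scatter of two such steps. This shows that the result of the change did not carry from one core to the other here, but two pairs cannot show which difference between the cores lies behind this, or how the change would behave on a further core.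

The compounds shown leave open whether another group at this place on the aromatic ring, such as an amine or a methoxy group, would give matching steps on both cores.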